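Moving a methoxy group around an ester ring

The source may report more compounds than this note shows. Statements on the series, on what has been measured and on what is new or still open speak of the compounds shown alone.

Measured compounds:
compound 1 `CC1=CC[C@H](C(C)C)c2cc(C)c(OC(=O)c3ccc(Cl)cc3)cc21`: 58.9%
compound 2 `COc1ccc(C(=O)Oc2cc3c(C)ccc(C(C)C)c3cc2C)cc1`: 88.6%
compound 3 `Cc1cc2c(C(C)C)ccc(C)c2cc1OC(=O)c1ccc(C(F)(F)F)cc1`: 45.1%

Three esters sharing one core were tested in a functional assay on K562 cells (Homo sapiens) for antiproliferative activity, read by sulforhodamine B assay, with a stated time of 48 h, tested at 50 uM; on this read-out higher numbers stand for more inhibition at the one concentration tested (going by the name of the read-out) and lower numbers for less inhibition. Compound 2 stands highest of the three; compound 1 sits lower with 58.9%, and compound 3 is furthest away at 45.1%. Among the measured compounds shown here, the one step that changes a single place, a number 43.5 percentage points lower from compound 2 to compound 3 (beyond the scatter), shows that swapping the group on the ester ring can move the read-out a long way.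

Compound 4 `COc1cccc(C(=O)Oc2cc3c(C)ccc(C(C)C)c3cc2C)c1` differs from compound 2 only in where the methoxy group sits: 3-methoxyphenyl in place of 4-methoxyphenyl on a carbonyl carbon. For the measured compounds named here, no measured step covers this kind of move, since compounds 1 and 3 change the group itself rather than its place. The large drop in a number 43.5 percentage points lower from compound 2 to compound 3 (beyond the scatter) only warns that this ring is sensitive. Because compound 2 gives 88.6%, the estimate for compound 4 is a somewhat lower number, 70%, in a range of 40% to 92%, which means an expected step of a number 18.6 percentage points lower from compound 2 to compound 4 (beyond the scatter).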

Compound 4, a percentage reported as inhibition, at one concentration (the size of the read-out at that concentration, not a potency): 14.2%
Compound 4: the middle estimate sits 55.8 percentage points above what was measured; the whole stated range lies above it.
By their numbers in this assay, from the lowest: compound 4; then compound 3; then compound 1; then compound 2.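

Compound 2 and compound 4 carry the same atoms and the same group, yet in this assay moving the methoxy group alone, from 4-methoxyphenyl to 3-methoxyphenyl, gives a number 74.4 percentage points lower from compound 2 to compound 4 (beyond the scatter). Among the compounds shown here, the earlier step, a number 43.5 percentage points lower from compound 2 to compound 3 (beyond the scatter), showed only that exchanging the group on this ring can matter, whereas this pair shows that the group's place on the ring can matter just as much, with nothing else changed. No measurement at hand explains why this move has so large an effect.

The compounds shown leave open whether the place matters in the same way for other groups on this ring, such as an ethoxy group, a hydroxyl group or an amine. They also leave open how either methoxy compound would behave at other concentrations, since each reading comes from a single one.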